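Swapping the Benzoyl Arene for Naphthalene: Cytotoxicity Outlook

The source may report more compounds than this note shows. Statements on the series, on what has been measured and on what is new or still open speak of the compounds shown alone.

The measured compounds and their values:
Compound 1, `O=C1c2ccccc2C(=O)N1CCOC(=S)N(C(=O)c1cc(F)cc(F)c1)c1ccc(Cl)cc1`: 59000 nM
Compound 2, `Cc1ccc(N(C(=O)c2cc(F)cc(F)c2)C(=S)OCCN2C(=O)c3ccccc3C2=O)cc1`: 54000 nM
Compound 3, `Cc1ccc(N(C(=O)c2ccc(Cl)c([N+](=O)[O-])c2)C(=S)OCCN2C(=O)c3ccccc3C2=O)cc1`: 47000 nM

In an ADME assay on MT4 cells (Homo sapiens) for cytotoxicity, read by MTT assay (on this read-out higher numbers stand for lower toxicity in this test and lower numbers for higher toxicity in this test), compound 1 gives the highest of the three numbers, yet every gap to the others lies within the scatter, so the three compounds cannot be told apart on this read-out. Compound 4, `O=C1c2ccccc2C(=O)N1CCOC(=S)N(C(=O)c1cccc2ccccc12)c1ccc(Cl)cc1`, is not yet measured. It differs from compound 1 in one place: naphthalen-1-yl in place of 3,5-difluorophenyl on a carbonyl carbon. The step that bears most on this change is a 1.1-fold lower number from compound 2 to compound 3 (0.06 log units; within the scatter), which also swaps the group on the carbonyl carbon; a 1.1-fold lower number from compound 1 to compound 2 (0.04 log units; within the scatter) was likewise flat. No change beyond the scatter is therefore expected for compound 4, and its estimated value is 50000 nM (range 25000 nM to 100000 nM), meaning an expected step of a 1.2-fold lower number from compound 1 to compound 4 (0.07 log units; within the scatter).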

Compound 4, half-maximal cytotoxic concentration: 6000 nM
Compound 4: middle estimate off by 8.3-fold (0.92 log units), on the high side; measured number below the stated range.
By their numbers in this assay, from the lowest: compound 4; then compounds 3, 2 and 1 (each within the scatter of the next).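

The group on the carbonyl carbon can matter after all: in this assay, naphthalen-1-yl in place of 3,5-difluorophenyl gives a 9.8-fold lower number from compound 1 to compound 4 (0.99 log units; beyond the scatter) and so moves the read-out towards higher toxicity in this test, whereas the earlier swap to 4-chloro-3-nitrophenyl stayed within the scatter. The flat earlier steps therefore did not show the full range of this position. Nothing at hand explains this shift. Still open, from the compounds shown here alone, is whether a naphthalen-2-yl or a plain phenyl group here would give a similar number, and whether the same swap would do the same on the methyl-bearing compound 2.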